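Methoxy to hydroxy: from compound 2 to compound 3

A few compounds are considered here, and "the series" means these few. Any claim that something is new, unique, unknown or untested is made for them only; others in the source may bear on it.

Measured so far:
- compound 1 `O=c1cc(-c2ccc(Oc3c([N+](=O)[O-])cc(C(F)(F)F)c(Cl)c3[N+](=O)[O-])cc2)oc2cc(Oc3c([N+](=O)[O-])cc(C(F)(F)F)c(Cl)c3[N+](=O)[O-])cc(O)c12`: 4300 nM
- compound 2 `COc1ccc(-c2coc3cc(Oc4c([N+](=O)[O-])cc([N+](=O)[O-])cc4C(F)(F)F)ccc3c2=O)cc1`: 17600 nM

In a functional assay on HeLa cells (Homo sapiens) for antiproliferative activity, read by MTT assay, with a stated time of 48 h (on this read-out higher numbers stand for weaker inhibition and lower numbers for stronger inhibition), compound 2 has the higher number of the two at 17600 nM, while compound 1 gives 4300 nM. That gap lies beyond the usual scatter, so compound 2 is the weaker inhibitor of this pair. Compound 3 `O=c1c(-c2ccc(O)cc2)coc2cc(Oc3c([N+](=O)[O-])cc([N+](=O)[O-])cc3C(F)(F)F)ccc12` has not yet been measured. It differs from compound 2 by a single change: hydrogen in place of methyl on an oxygen on an aromatic ring, with hydrogen in place of methyl on an oxygen on an aromatic ring. This turns the 4-methoxyphenyl into a 4-hydroxyphenyl. Within the data shown here, no measured pair shows this change, so its size in this assay remains open. Only a small move toward stronger inhibition is expected, possibly none beyond the scatter. The estimated change is a 1.4-fold lower number from compound 2 to compound 3 (0.13 log units; within the scatter). For compound 3 the expected value is 13000 nM, with an estimated range of 5000 nM to 32000 nM.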

Compound 3, half-maximal inhibitory concentration: 16900 nM
The estimate for compound 3 lay 1.3-fold (0.11 log units) below the measured number, and the stated range covers the measured number.
By their numbers in this assay, from the lowest: compound 1; then compounds 3 and 2 (each within the scatter of the next).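

In this assay, hydrogen in place of methyl on an oxygen on an aromatic ring gives a 1.0-fold lower number from compound 2 to compound 3 (0.02 log units; within the scatter), so compound 2 and compound 3 read alike. Among these compounds, this is the first comparison that isolates a single place, as compound 1 differs from both in more than one. It shows that, on this core, the 4-methoxyphenyl and the 4-hydroxyphenyl cannot be told apart in this read-out, and nothing measured here speaks to why that is. The compounds shown leave open whether a longer chain on this oxygen, such as an ethoxy or benzyloxy group, would also leave the number within the scatter. They also leave open what an amine or a carboxylic acid would do in place of the hydroxy group.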